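Compound 3 and its (1-carboxy-2-hydroxypropyl)amino analogue

The source may hold more compounds than are shown below. What is called first, only, known or untested is meant among the compounds shown, and "the series" means these compounds.

Measured in a functional assay on HeLa cells (Homo sapiens) for antiproliferative activity, read by CCK-8 assay, with a stated time of 48 h; a lower number here means a stronger inhibitor, a higher number a weaker inhibitor:
- compound 1 `COc1ccc(/C=C\c2cc(OC)c(OC)c(OC)c2)cc1OCc1ccc(CN2C[C@H](O)C[C@@H]2C(=O)O)cc1`: > 10000 nM (a limit of the assay)
- compound 2 `COc1ccc(/C=C\c2cc(OC)c(OC)c(OC)c2)cc1OCc1ccc(CNCCO)cc1`: 4400 nM
- compound 3 `COc1ccc(/C=C\c2cc(OC)c(OC)c(OC)c2)cc1OCc1ccc(CO)cc1`: 7600 nM

Compound 3 gives 7600 nM in this assay. Among the compounds with values here, the only other exact number lies close to it, with a 1.7-fold higher number from compound 2 to compound 3 (0.24 log units; within the scatter). Compound 1 reports only a limit, > 10000 nM.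

Compound 4 `COc1ccc(/C=C\c2cc(OC)c(OC)c(OC)c2)cc1OCc1ccc(CN[C@H](C(=O)O)[C@@H](C)O)cc1` keeps the shared core of compound 3 and changes one group. The difference, ((1-carboxy-2-hydroxypropyl)amino in place of hydroxy on a saturated chain carbon bound to an aromatic carbon), puts (1-carboxy-2-hydroxypropyl)amino in place of hydroxy on a saturated chain carbon bound to an aromatic carbon.

Within the data shown here, two measured steps bear on this change, both starting from the carboxy-bearing group of compound 1, and both are bounded on one side only. Replacing that group with hydroxy gave an at least 1.3-fold lower number from compound 1 to compound 3 (0.11 log units; that floor lies within the scatter). Replacing it with (2-hydroxyethyl)amino gave an at least 2.2-fold lower number from compound 1 to compound 2 (0.35 log units; beyond the scatter). The entering group of compound 4 also carries carboxy, so it is expected to behave more like compound 1, and the floor of an at least 1.3-fold lower number from compound 1 to compound 3 (0.11 log units; that floor lies within the scatter) suggests only a small upward move in this assay. The expected step is a 1.4-fold higher number from compound 3 to compound 4 (0.16 log units; within the scatter). Compound 4 is estimated at 11000 nM, with an expected range of 5000 nM to 30000 nM.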

Compound 4, half-maximal inhibitory concentration: > 10000 nM
Compound 4 gave a limit, no number; the forecaster's own chance of this, stated with the estimate: 50%; the middle value lies beyond the limit too.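

In this assay compound 4 reports only a limit, > 10000 nM, so a carboxy-bearing group with no ring, (1-carboxy-2-hydroxypropyl)amino, ends in the same place as the 2-carboxy-4-hydroxypyrrolidin-1-yl group of compound 1. On the amine nitrogen, 1-carboxy-2-hydroxypropyl in place of 2-hydroxyethyl gives an at least 2.2-fold higher number from compound 2 to compound 4 (0.35 log units; beyond the scatter), which shows that keeping this nitrogen does not by itself hold the value of compound 2, whereas the change from hydroxy gives an at least 1.3-fold higher number from compound 3 to compound 4 (0.11 log units; that floor lies within the scatter), a floor that does not separate compound 4 from compound 3. Among these compounds, the two that carry carboxy are the two that give no exact number, with no compound going against this, and both rest at the same assay limit: the limit of > 10000 nM in this assay, at which 2 of the 4 values shown sit.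

On these data alone, the step from compound 1 to compound 4 cannot be read, as both values are limits, and how far either compound lies beyond its limit stays unknown. As far as these compounds go, it also remains open whether the carboxylic acid itself or the added chain accounts for the step from compound 2, which a methyl ester or a primary amide in place of the carboxy group could help to separate.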